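A few compounds are considered here, and "the series" means these few. Any claim that something is new, unique, unknown or untested is made for them only; others in the source may bear on it.

The three measured compounds are compound 1 `COc1cc(OC)c2sc(-c3ccc(N/C=C\C(=O)c4ccc(OC)c([N+](=O)[O-])c4)c(C)c3)nc2c1`, compound 2 `COc1cc(OC)c2sc(-c3ccc(N/C=C\C(=O)c4ccc(OC)c([N+](=O)[O-])c4)cc3)nc2c1` and compound 3 `COc1ccc2nc(-c3ccc(N/C=C\C(=O)c4ccc(OC)c([N+](=O)[O-])c4)cc3)sc2c1`. In a functional assay on HeLa cells (Homo sapiens) for antiproliferative activity, read by sulforhodamine B assay, with a stated time of 48 h (on this read-out higher numbers stand for weaker inhibition and lower numbers for stronger inhibition), compound 1 gives 9390 nM, compound 2 gives 12900 nM and compound 3 gives 17600 nM. Compound 1 carries, relative to compound 2, (methyl in place of hydrogen on an aromatic carbon); this change produced a 1.4-fold lower number from compound 2 to compound 1 (0.14 log units; within the scatter). Compound 3 shares much of its structure with compound 2, but the difference between the two cores is not broken down here, and their two values lie within the scatter of each other.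

Compound 4 `COc1ccc2nc(-c3ccc(N/C=C\C(=O)c4ccc(OC)c([N+](=O)[O-])c4)c(C)c3)sc2c1` has not yet been measured in this assay. It differs from compound 3 by methyl in place of hydrogen on an aromatic carbon. This is the same kind of change as that made from compound 2 to compound 1, though here the place is meta to a 6-methoxy-1,3-benzothiazol-2-yl group rather than meta to a large group. Because a 1.4-fold lower number from compound 2 to compound 1 (0.14 log units; within the scatter) was seen on the other core, the estimated step in this assay is a 1.4-fold lower number from compound 3 to compound 4 (0.15 log units; within the scatter), a small one that stays within the scatter. On that basis compound 4 is expected to give about 12500 nM in this assay, with a likely range from 6000 nM to 26000 nM.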

Compound 4, half-maximal inhibitory concentration: 17600 nM
Beside the measured number, compound 4's estimate is 1.4-fold (0.15 log units) below it; low and high end bracket the measured number.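

In this assay, methyl in place of hydrogen on an aromatic carbon, ortho to a large group and meta to a 6-methoxy-1,3-benzothiazol-2-yl group, produces no change at the digits printed from compound 3 to compound 4 (within the scatter). Set beside the step on the other core, this result shows that the two steps do not differ beyond what repeated measurements would scatter: the same change on two cores in this assay, a 1.4-fold lower number (0.14 log units; within the scatter) from compound 2 to compound 1 and no change at the digits printed (within the scatter) from compound 3 to compound 4, 1.4-fold (0.14 log units) apart, within the scatter of two such steps The change therefore carries from the core of compound 1 to the core of compound 4 without any visible departure, but with both steps within the scatter, this pair of cores does not show that the methyl changes the read-out on either core, nor does it show that a real effect transfers from one core to the other.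

The compounds shown leave open whether a larger or different group at this place, such as an ethyl chain, a chlorine atom or an amine, would give a step beyond the scatter. They also leave open whether the two cores would then respond alike.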